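Swapping a pentyl chain for a methoxyphenyl ring

The source may hold more compounds than are shown below. What is called first, only, known or untested is meant among the compounds shown, and "the series" means these compounds.

Compound 3 `CCCCCNc1nc2ccc(NC(=O)c3c(Cl)cccc3Cl)cc2s1` gives 0.27 ug/mL in a functional assay on WI-38 VA13 cells (Homo sapiens) for cytotoxicity (on this read-out higher numbers stand for an effect only at larger amounts of compound and lower numbers for an effect already at smaller amounts), the highest of the three numbers recorded. Compound 1 `O=C(Nc1ccc2nc(NC(=O)C3CCC3)sc2c1)c1c(Cl)cccc1Cl` gives 0.013 ug/mL and compound 2 `COCCOC(=O)Nc1nc2ccc(NC(=O)c3c(Cl)cccc3Cl)cc2s1` gives 0.011 ug/mL in this assay. Both carry a carbonyl group on a nitrogen on an aromatic ring, and moving to pentyl brought a 21-fold higher number from compound 1 to compound 3 (1.32 log units; beyond the scatter) and a 25-fold higher number from compound 2 to compound 3 (1.39 log units; beyond the scatter), while a 1.2-fold lower number from compound 1 to compound 2 (0.07 log units; within the scatter). Compound 4 `COc1ccccc1Nc1nc2ccc(NC(=O)c3c(Cl)cccc3Cl)cc2s1` differs from compound 3 by 2-methoxyphenyl in place of pentyl on a nitrogen on an aromatic ring. Among the compounds with values here, no measured step covers an aromatic ring at this place; the two large steps show only that carbonyl-bearing groups went with much lower numbers than pentyl. The expected step in this assay is therefore small: a 1.8-fold lower number from compound 3 to compound 4 (0.26 log units; within the scatter). The number estimated for compound 4 is 0.15 ug/mL, with a range from 0.03 ug/mL to 0.8 ug/mL.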

Compound 4, half-maximal effective concentration: > 7.2 ug/mL
Compound 4: no number, only a limit; the forecaster's own chance of this, stated with the estimate: 5%; middle value at least 48-fold (1.68 log units) from the limit.
By their numbers in this assay, from the lowest: compounds 2 and 1 (each within the scatter of the next); then compound 3. At a limit, above all of these: compound 4.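

In this assay compound 4 gives only a limit of the assay, not a number: the limit of > 7.2 ug/mL in this assay, at which 1 of the 4 values shown sits. Even without a carbonyl on this nitrogen, the group there still matters: 2-methoxyphenyl in place of pentyl brings an at least 26-fold higher number from compound 3 to compound 4 (1.42 log units; beyond the scatter). Set against the carbonyl-bearing groups, the same ring gives an at least 650-fold higher number from compound 2 to compound 4 (2.81 log units; beyond the scatter) and an at least 550-fold higher number from compound 1 to compound 4 (2.74 log units; beyond the scatter).

The compounds shown leave open whether this shift goes with the aromatic ring itself or with its methoxy group. A plain phenyl ring or a benzyl group on this nitrogen would separate those two readings.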